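The source may report more compounds than this note shows. Statements on the series, on what has been measured and on what is new or still open speak of the compounds shown alone.

In a functional assay on SW-620 cells (Homo sapiens) for cytotoxicity, read by colorimetric assay (a higher number here means a weaker inhibitor, a lower number a stronger inhibitor), compound 1 `Cc1ccc2c(c1)/C(=C1/Nc3ccccc3/C1=N\O)C(=O)N2Cc1ccc(/C=C/C(=O)NO)cc1` gives 50 nM. Compound 2 `Cc1ccc2c(c1)/C(=C1/Nc3ccccc3/C1=N\O)C(=O)N2Cc1ccc(C(=O)NO)cc1` gives 30 nM and compound 3 `O=C(NO)c1ccc(CN2C(=O)/C(=C3\Nc4ccccc4\C3=N/O)c3cccc(Cl)c32)cc1` gives 90 nM, so compound 1 lies within the scatter of both. Compound 4 `O=C(/C=C/c1ccc(CN2C(=O)/C(=C3\Nc4ccccc4\C3=N/O)c3cc(Br)ccc32)cc1)NO` keeps the core and the 2-(hydroxycarbamoyl)ethenyl chain of compound 1 but has bromo in place of methyl on an aromatic carbon.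

Within the data shown here, no measured step makes this exchange directly. The only one available, a 1.7-fold lower number from compound 1 to compound 2 (0.22 log units; within the scatter), swaps 2-(hydroxycarbamoyl)ethenyl for hydroxycarbamoyl, a change elsewhere in the molecule, and it stays within the scatter. Compound 3 offers a loose hint: it carries chloro rather than methyl on the core and gives 90 nM, within the scatter of compound 1 at 50 nM. No step beyond the scatter is therefore expected in this assay, and no direction can be called with confidence. The expected change is a 1.1-fold lower number from compound 1 to compound 4 (0.05 log units; within the scatter). For compound 4 the estimated value is 45 nM, with an expected range from 18 nM to 120 nM.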

Compound 4, half-maximal inhibitory concentration: 60 nM
Compound 4: middle estimate off by 1.3-fold (0.12 log units), on the low side; measured number inside the range.
By their numbers in this assay, from the lowest: compounds 2, 1, 4 and 3 (each within the scatter of the next, the first and the last beyond it).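

In this assay, putting bromo in place of methyl on this aromatic carbon gives a 1.2-fold higher number from compound 1 to compound 4 (0.08 log units; within the scatter), so the two compounds cannot be told apart. Among these compounds, this is the first direct reading of a change at this position with the rest of the molecule held fixed, including the 2-(hydroxycarbamoyl)ethenyl chain, and it shows that methyl and bromo are interchangeable here in this cell assay. Nothing measured on these compounds explains why the two groups read alike.

Methyl and bromo are only two possible groups at this carbon, so it remains open whether an amine, a methoxy group or a carboxylic acid there would give a similar number. On these data alone, it is also open whether bromo would read the same alongside the shorter hydroxycarbamoyl group of compound 2.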